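The source may hold more compounds than are shown below. What is called first, only, known or untested is meant among the compounds shown, and "the series" means these compounds.

Measured compounds:
Compound 1, `COc1ccc2c(=O)c(/C=C/C(=O)Nc3cccc(Cl)c3)coc2c1` — > 100000 nM
Compound 2, `COc1ccc2c(=O)c(/C=C/C(=O)Nc3ccccc3C)coc2c1` — 26900 nM

In a functional assay on Huh-7 cells (Homo sapiens) for inhibition, read by MTT assay, with a stated time of 48 h (on this read-out lower numbers stand for stronger inhibition and higher numbers for weaker inhibition), compound 1 reaches only a limit, (the limit of > 100000 nM in this assay, at which 1 of the 2 values shown sits). Among the measured compounds shown here, compound 2 is the one compound with an actual number in this assay, 26900 nM. For the measured compounds named here, the single measured step, an at least 3.7-fold lower number from compound 1 to compound 2 (0.57 log units; beyond the scatter), shows that exchanging the ring on the amide-type nitrogen can move the read-out. Compound 3, `COc1ccc2c(=O)c(/C=C/C(=O)Nc3ccc(C)cc3)coc2c1`, differs from compound 2 by 4-methylphenyl in place of 2-methylphenyl on an amide-type nitrogen. Going by the values given here, no measured step covers this change, so the expectation for compound 3 is a step of a 1.5-fold higher number from compound 2 to compound 3 (0.17 log units; within the scatter) and an estimated value of 40000 nM, between 10000 nM and 150000 nM.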

Compound 3, half-maximal inhibitory concentration: > 100000 nM
Compound 3: only a limit was reported (the forecaster's own chance of this, stated with the estimate: 30%); middle value at least 2.5-fold (0.39 log units) from the limit.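

In this assay, the change from 2-methylphenyl to 4-methylphenyl on the amide-type nitrogen keeps the same atoms yet gives an at least 3.7-fold higher number from compound 2 to compound 3 (0.57 log units; beyond the scatter), so the read-out at this place depends on where the methyl sits on the ring, not only on which ring is present. The step between compound 1 and compound 3 cannot be read, since each gives only a limit: the limit of > 100000 nM in this assay, at which 2 of the 3 values shown sit.

The compounds shown leave open whether an amine or a carboxylic acid in place of the methyl of 2-methylphenyl would keep a measurable number or lower it further.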